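A few compounds are considered here, and "the series" means these few. Any claim that something is new, unique, unknown or untested is made for them only; others in the source may bear on it.

Measured so far in a functional assay on HCT-116 cells (Homo sapiens) for cytotoxicity, read by MTT assay, with a stated time of 48 h; on this read-out higher numbers stand for weaker inhibition and lower numbers for stronger inhibition:
- compound 1 `COc1cc(/C=C/C(=O)C2=C(/C=C/c3ccc(O)c(OC)c3)NC(=O)NC2c2ccc(C)cc2)ccc1O`: 12500 nM
- compound 2 `COc1cc(/C=C/C(=O)C2=C(/C=C/c3ccc(O)c(OC)c3)NC(=O)NC2c2cccc([N+](=O)[O-])c2)ccc1O`: 50000 nM

Of these two, compound 2 holds the higher number, 50000 nM, which on this read-out means weaker inhibition. The next compound, compound 3 `COc1cc(/C=C/C(=O)C2=C(/C=C/c3ccc(O)c(OC)c3)NC(=O)NC2c2ccccc2Cl)ccc1O`, keeps the shared core and changes one group, with 2-chlorophenyl in place of 3-nitrophenyl on a saturated ring carbon.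

Among the measured compounds shown here, only one measured step bears on this change. It concerns the same kind of ring carbon, where 3-nitrophenyl took the place of 4-methylphenyl: a 4.0-fold higher number from compound 1 to compound 2 (0.60 log units; beyond the scatter). That step is modest but beyond the scatter. Compound 3 gives up the 3-nitrophenyl group, and compound 1, which lacks that group too, gives 12500 nM. A modest move to a lower number in this assay is therefore expected. For the measured compounds named here, no measured compound carries 2-chlorophenyl, so this single step is a thin guide and the range must stay wide.

The expected change is a 2.5-fold lower number from compound 2 to compound 3 (0.40 log units; beyond the scatter). For compound 3 the estimated value is 20000 nM, with an expected range from 7000 nM to 55000 nM.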

Compound 3, half-maximal inhibitory concentration: 50000 nM
The estimate for compound 3 lay 2.5-fold (0.40 log units) below the measured number; low and high end bracket the measured number.
By their numbers in this assay, from the lowest: compound 1; then compounds 2 and 3 (each within the scatter of the next).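

In this assay, placing 2-chlorophenyl where 3-nitrophenyl stood gives no change at the digits printed from compound 2 to compound 3 (within the scatter), so these two groups on the saturated ring carbon cannot be told apart in this test, even though they differ in their added substituent and in where it sits on the phenyl ring. The comparison with 4-methylphenyl gives a 4.0-fold higher number from compound 1 to compound 3 (0.60 log units; beyond the scatter), matching in size a 4.0-fold higher number from compound 1 to compound 2 (0.60 log units; beyond the scatter), so among these three compounds the higher number is not tied to the nitro group, and compound 1 alone stands apart. Nothing measured here explains why the three values fall this way.

Among the compounds shown here, with only three groups at this carbon, it remains open whether the lower number of compound 1 depends on the methyl group itself or on its place on the phenyl ring. A plain phenyl group would help separate these two readings, while a phenyl ring carrying an amine or a carboxylic acid would show whether this position responds to groups of a quite different kind.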